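Adding a second methyl to the pyridine amide of compound 3

The compounds below may be only part of what the source reports. "The series", "measured", "known", "first", "only" and "open" are said of these compounds alone.

Three pyridine carboxamides were tested in a functional assay on the whole organism for inhibition, with Rattus norvegicus as the target, at a dose of 3 mg/kg by the oral route; on this read-out lower numbers stand for a weaker effect and higher numbers for a stronger effect at the one dose given. Compound 1 `Cc1cccc(C(=O)Nc2nn[nH]n2)n1` gives 46%, compound 2 `CC(C)c1ccnc(C(=O)Nc2nn[nH]n2)c1` gives 34%, and compound 3 `Cc1ccnc(C(=O)Nc2nn[nH]n2)c1` gives 42%. Within the data shown here, compound 3 therefore sits within the scatter of both compound 1 and compound 2, and the one single-change step, a number 8 percentage points higher from compound 2 to compound 3 (within the scatter), also stays within the scatter. Compound 4 `Cc1cc(C)nc(C(=O)Nc2nn[nH]n2)c1` has not yet been measured; it differs from compound 3 by methyl in place of hydrogen on an aromatic carbon. Only the methyl-for-isopropyl step bears on this change, and it was small. The step of a number 2 percentage points higher from compound 3 to compound 4 (within the scatter) is therefore expected to stay within the scatter. Compound 4 is estimated to give 44%, within a range of 30% to 58%.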

Compound 4, a percentage reported as inhibition, in the whole organism at one dose (the size of the read-out at that dose, not a potency): 44%
The estimate for compound 4 equals the measured number at the digits printed; measured number inside the range.
By their numbers in this assay, from the lowest: compounds 2, 3, 4 and 1 (each within the scatter of the next, the first and the last beyond it).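

In this assay, methyl in place of hydrogen on the aromatic carbon next to the ring nitrogen gives a number 2 percentage points higher from compound 3 to compound 4 (within the scatter). Compound 4 also carries the methyl of compound 1, and the second comparison gives a number 2 percentage points lower from compound 1 to compound 4 (within the scatter), so from either compound the added methyl leaves the two numbers within the scatter of each other. Nothing available explains this result.

From the compounds shown here alone, whether an ethyl chain, an amine or a carboxylic acid at this place would give a step beyond the scatter remains open. So does the outcome at other doses.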